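This account rests on a few compounds, and the source may have more. Where it says the series, first, only, none or still open, it means among the compounds named here.

Measured so far in an ADME assay on Raji cells (Homo sapiens) for inhibition, with a stated time of 72 h; a lower number here means that less compound is needed, a higher number that more compound is needed for the effect:
- compound 1, `CN(C)CCC(=O)Nc1cccc(-c2nc3ccccc3s2)c1`: > 25000 nM, a limit of the assay
- compound 2, `CC(C)(CCl)C(=O)Nc1cccc(-c2nc3ccccc3s2)c1`: > 25000 nM, a limit of the assay
- compound 3, `O=C(Nc1cccc(-c2nc3ccccc3s2)c1)c1cc([N+](=O)[O-])cnc1Cl`: 8400 nM

Compound 2 stands at a limit of this assay, not at a number. Compound 1 stands at the same limit, so the step from compound 1 to compound 2 is a step that the two limits leave unreadable from compound 1 to compound 2 and yields no size. Of the three values shown, two sit at the limit of > 25000 nM in this assay, at which 2 of the 3 values shown sit; only compound 3, with 8400 nM in this assay, gives a number.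

Compound 4 is `O=C(Nc1cccc(-c2nc3ccccc3s2)c1)c1cnc(Cl)s1`. It differs from compound 2 by 2-chloro-1,3-thiazol-5-yl in place of 1-(chloromethyl)-1-methylethyl on a carbonyl carbon. Going by the values given here, no measured step covers this exchange; the only step in hand, the one from compound 1 to compound 2, cannot be read. Among the compounds with values here, the one number in the set, that of compound 3, shows that a substituent of a different kind on the carbonyl carbon can bring the series below the limit, but this is a single point.

The estimate for compound 4 in this assay is therefore 15000 nM, with a range from 5000 nM to 30000 nM. The step from compound 2 to compound 4 is expected to be an at least 1.6-fold lower number from compound 2 to compound 4 (0.22 log units; that floor lies within the scatter), toward a lower number, though a reading against a limit may remain impossible.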

Compound 4, half-maximal effective concentration: > 25000 nM
Compound 4: no number, only a limit; the forecaster's own chance of this, stated with the estimate: 45%; middle value at least 1.6-fold (0.22 log units) away from the limit.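

In this assay compound 4 gives > 25000 nM, which is a limit and not a number. Its steps from compound 1 and compound 2, which also stand at a limit, cannot be read: the limit of > 25000 nM in this assay, at which 3 of the 4 values shown sit.

The compounds shown leave open how far compound 1, compound 2 and compound 4 lie from that limit, and so how far each stands from compound 3.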